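The source may hold more compounds than are shown below. What is called first, only, known or untested is meant among the compounds shown, and "the series" means these compounds.

Compound 1 `CCCCNC(=O)Nc1cccc2c1CN(C)CC2c1ccccc1` gives 69 mg/kg in a functional assay on the whole organism for inhibition of sodium-dependent dopamine transporter (Mus musculus); on this read-out higher numbers stand for an effect only at larger amounts of compound and lower numbers for an effect already at smaller amounts.
Compound 2 `CCNCC(=O)Nc1cccc2c1CN(C)CC2c1ccccc1` gives about 60 mg/kg in this assay.
Compound 3 `CCCCNCC(=O)Nc1cccc2c1CN(C)CC2c1ccccc1` gives 25 mg/kg in this assay.

Compound 3 has the lowest number of the three measured compounds. Its separation from compound 2 is a 2.4-fold lower number from compound 2 to compound 3 (0.38 log units; beyond the scatter), and from compound 1 it is a 2.8-fold lower number from compound 1 to compound 3 (0.44 log units; beyond the scatter), both beyond the scatter, so on these numbers compound 3 is the most potent of the measured set. The step from compound 1 to compound 2, a 1.2-fold lower number from compound 1 to compound 2 (0.06 log units; within the scatter), lies within the scatter.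

Compound 4 `CC(C)NCCC(=O)Nc1cccc2c1CN(C)CC2c1ccccc1` differs from compound 3 by (isopropylamino)methyl in place of butylamino on a saturated chain carbon bound to a carbonyl carbon. Among the compounds with values here, two measured steps bear on this change. The step of a 2.4-fold lower number from compound 2 to compound 3 (0.38 log units; beyond the scatter) shows that a longer alkyl on the amine nitrogen goes with a lower number; the step of a 2.8-fold lower number from compound 1 to compound 3 (0.44 log units; beyond the scatter) shows that a saturated carbon inserted between the carbonyl and the amine nitrogen also goes with a lower number. Compound 4 extends the linker by another carbon but carries a shorter, branched alkyl on the nitrogen, so these two tendencies pull in opposite directions. Within the data shown here, no measured pair tests a branched alkyl or a two-carbon linker. He therefore expects in this assay for compound 4 a step of a 1.6-fold higher number from compound 3 to compound 4 (0.20 log units; within the scatter), likely within the scatter. His estimate for compound 4 in this assay is 40 mg/kg, with a range from 15 mg/kg to 110 mg/kg.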

Compound 4, dose for half-maximal effect: about 200 mg/kg
Compound 4: the middle estimate sits 5.0-fold (0.70 log units) below what was measured, outside the stated range (above it).
By their numbers in this assay, from the lowest: compound 3; then compounds 2 and 1 (each within the scatter of the next); then compound 4.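

In this assay, within the data shown here, the change on a saturated chain carbon bound to a carbonyl carbon proves far less tolerated than the earlier compounds suggested: the number rises (an 8.0-fold higher number from compound 3 to compound 4 (0.90 log units; beyond the scatter)), a larger step than any among compound 1, compound 2 and compound 3. Compound 4 also stands above the compound carrying the shorter ethylamino group (a 3.3-fold higher number from compound 2 to compound 4 (0.52 log units; beyond the scatter)) and above the compound with butylamino directly on the carbonyl carbon (a 2.9-fold higher number from compound 1 to compound 4 (0.46 log units; beyond the scatter)), so the lower number seen on going from butylamino to (butylamino)methyl on that carbon does not carry over to 2-(isopropylamino)ethyl. Nothing measured alongside these numbers accounts for the rise.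

The step changes both the branching of the alkyl group and the length of the chain, so the compounds shown cannot assign the rise to either one; 2-(butylamino)ethyl and (isopropylamino)methyl on the carbonyl carbon are the groups that would separate the two. Also open, as far as these compounds go, is how a longer unbranched alkyl on the amine nitrogen, such as pentyl, or a cyclic amine such as piperidine, would read at this place.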